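This account rests on a few compounds, and the source may have more. Where it says the series, first, only, none or still open, it means among the compounds named here.

- Compound 1 `Cc1ccccc1C(=O)Nc1nc(-c2ccccn2)cs1`: 6300 nM
- Compound 2 `COc1ccc(C(=O)Nc2nc(-c3ccccn3)cs2)cc1`: 9200 nM
- Compound 3 `CC(=O)c1ccc(C(=O)Nc2nc(-c3ccccn3)cs2)cc1`: 10500 nM

In an ADME assay on Vero cells (Chlorocebus sabaeus) for cytotoxicity, read by MTT assay, with a stated time of 72 h (on this read-out lower numbers stand for an effect already at smaller amounts and higher numbers for an effect only at larger amounts of compound), compound 1 gives 6300 nM, which lies within the scatter of both other compounds, so the three cannot be ranked. Compound 4 `O=C(Nc1nc(-c2ccccn2)cs1)c1cccc(Br)c1` has 3-bromophenyl in place of 2-methylphenyl on a carbonyl carbon. For the measured compounds named here, only one measured step bears on this, and only loosely: a 1.1-fold higher number from compound 2 to compound 3 (0.06 log units; within the scatter), with acetyl in place of methoxy on an aromatic carbon. Going by the values given here, no measured compound carries bromine. A step beyond the scatter is therefore not expected, and no direction can be favoured. The expected change is small, an estimated 1.2-fold higher number from compound 1 to compound 4 (0.08 log units; within the scatter). For compound 4 the estimated value is 7500 nM, with an expected range from 3500 nM to 16000 nM.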

Compound 4, half-maximal effective concentration: 16100 nM
The estimate for compound 4 lay 2.1-fold (0.33 log units) below the measured number; measured number above the stated range.
By their numbers in this assay, from the lowest: compounds 1, 2, 3 and 4 (each within the scatter of the next, the first and the last beyond it).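

In this assay the change to 3-bromophenyl in place of 2-methylphenyl on a carbonyl carbon gives a 2.6-fold higher number from compound 1 to compound 4 (0.41 log units; beyond the scatter) and is the only step shown that lies beyond the scatter. The earlier step, a 1.1-fold higher number from compound 2 to compound 3 (0.06 log units; within the scatter), did not show this, so this position on the shared core can move the number, if modestly. No evidence is available to explain the step. From the compounds shown here alone, whether it belongs to the bromine or to the departing methyl remains open, since both change at once. Also open, going by these compounds, is how a phenyl carrying an amine or a carboxylic acid would read here.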